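Sulfonamide nitrogen variation on the shared anilide core

The source may report more compounds than this note shows. Statements on the series, on what has been measured and on what is new or still open speak of the compounds shown alone.

Three compounds share the core of compound 1 `CC(O)(C(=O)Nc1ccc(S(=O)(=O)N2CCNCC2)cc1)C(F)(F)F` and differ only at the sulfonyl sulfur. In an assay on a protein complex (Cavia porcellus) with sulfonylurea receptors; K-ATP channels (Homo sapiens) as the target (on this read-out lower numbers stand for stronger inhibition and higher numbers for weaker inhibition), compound 1 reaches only a limit, > 30000 nM. Compound 2 `CC(O)(C(=O)Nc1ccc(S(N)(=O)=O)cc1)C(F)(F)F` gives 12800 nM in this assay, and compound 3 `CCCN(CCC)S(=O)(=O)c1ccc(NC(=O)C(C)(O)C(F)(F)F)cc1` gives 6440 nM. The step of an at least 2.3-fold lower number from compound 1 to compound 2 (0.36 log units; beyond the scatter) and the step of an at least 4.6-fold lower number from compound 1 to compound 3 (0.66 log units; beyond the scatter) both run toward lower numbers; the step of a 2.0-fold lower number from compound 2 to compound 3 (0.30 log units; within the scatter) stays within the scatter, so compound 3 and compound 2 sit together, with the third value being a limit.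

Compound 4 `CC(O)(C(=O)Nc1ccc(S(=O)(=O)N2CCSCC2)cc1)C(F)(F)F` is not yet measured. Relative to compound 3 it carries thiomorpholin-4-yl in place of dipropylamino on a sulfonyl sulfur. Among the measured compounds shown here, the steps that bear on this are the ring-amine replacement an at least 4.6-fold lower number from compound 1 to compound 3 (0.66 log units; beyond the scatter) and the open-chain comparison a 2.0-fold lower number from compound 2 to compound 3 (0.30 log units; within the scatter); thiomorpholin-4-yl is a ring amine, as in compound 1, but it lacks the hydrogen-bond donor counted there. A modest step toward a higher number is therefore expected, a 1.4-fold higher number from compound 3 to compound 4 (0.15 log units; within the scatter), possibly within the scatter. Compound 4 is estimated at 9000 nM in this assay, with a range from 3500 nM to 30000 nM.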

Compound 4, half-maximal inhibitory concentration: 4580 nM
Compound 4: middle estimate off by 2.0-fold (0.29 log units), on the high side; measured number inside the range.
By their numbers in this assay, from the lowest: compounds 4, 3 and 2 (each within the scatter of the next, the first and the last beyond it). At a limit, above all of these: compound 1.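

In this assay, a ring amine on a sulfonyl sulfur does not by itself place a compound at the high end of the series, as thiomorpholin-4-yl in place of piperazin-1-yl gives an at least 6.5-fold lower number from compound 1 to compound 4 (0.81 log units; beyond the scatter); the value of compound 1 is a limit and not a number, so this step has no fixed size: the limit of > 30000 nM in this assay, at which 1 of the 4 values shown sits.

Thiomorpholin-4-yl is also the first group here to separate clearly from amino, with a 2.8-fold lower number from compound 2 to compound 4 (0.45 log units; beyond the scatter). The ring and the open chain are not separated, however, with a 1.4-fold lower number from compound 3 to compound 4 (0.15 log units; within the scatter).

From the compounds shown here alone, it remains open whether the ring sulfur of compound 4 matters at all, a question that morpholin-4-yl or piperidin-1-yl would address. Also open, going by these compounds, is whether 4-methylpiperazin-1-yl would stay at the level of compound 1 or move toward that of compound 4.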